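The source may hold more compounds than are shown below. What is called first, only, known or untested is meant among the compounds shown, and "the series" means these compounds.

The measured compounds are compound 1 `CC[C@@H]1C(=O)N(C)c2cnc(Nc3ccc(S(=O)(=O)NC4CCCC4)cc3)nc2N1C1CCCC1`, which in an assay for inhibition of serine/threonine-protein kinase PLK2 (Homo sapiens), read by FRET and Z'-LYTE, with a stated time of 1 h (on this read-out higher numbers stand for weaker inhibition and lower numbers for stronger inhibition), gives 23.9 nM, and compound 2 `CCC1C(=O)N(C)c2cnc(Nc3ccc(S(=O)(=O)NCCCO)cc3)nc2N1c1ccn(C)n1`, which in this assay gives 192 nM.

Among the compounds with values here, compound 2 stands at the higher of the two numbers; compound 1 lies lower, and the gap between the two values is beyond the usual scatter, although the two compounds differ in more than one place and no single step is traced between them.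

Compound 3 `CCCCNS(=O)(=O)c1ccc(Nc2ncc3c(n2)N(c2ccn(C)n2)C(CC)C(=O)N3C)cc1` is not yet measured. It differs from compound 2 by methyl in place of hydroxy on a saturated chain carbon, three bonds along the chain from a sulfonamide nitrogen. Within the data shown here, no pair of measured compounds isolates this change, so nothing in the data sets its direction. On that basis the step from compound 2 to compound 3 is expected to be small, and likely within the scatter, giving a 1.3-fold lower number from compound 2 to compound 3 (0.11 log units; within the scatter). For compound 3 in this assay the estimate is 150 nM, with a range from 60 nM to 400 nM.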

Compound 3, half-maximal inhibitory concentration: 191 nM
Compound 3: middle estimate off by 1.3-fold (0.10 log units), on the low side, and the stated range covers the measured number.
By their numbers in this assay, from the lowest: compound 1; then compounds 3 and 2 (each within the scatter of the next).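

In this assay, within the data shown here, putting methyl in place of hydroxy on a saturated chain carbon, three bonds along the chain from a sulfonamide nitrogen, gives a 1.0-fold lower number from compound 2 to compound 3 (0.00 log units; within the scatter), the first step that isolates a single change. With the rest of the molecule held fixed, the 3-hydroxypropyl and butyl forms of the chain cannot be told apart on this read-out, even though hydroxy counts as a hydrogen-bond donor and acceptor and methyl as neither. Nothing shown gives a reason for this result.

From the compounds shown here alone, it remains open whether an amine, a carboxylic acid or a longer chain in place of the hydroxy would also leave the number within the scatter. The compounds shown also leave open whether methyl in place of hydroxy would read the same way with the cyclopentyl group of compound 1 on the shared core.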